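A hydroxyphenyl in place of a pentylphenyl: cytotoxicity outlook

This account rests on a few compounds, and the source may have more. Where it says the series, first, only, none or still open, it means among the compounds named here.

Compound 1 `Cc1ccc(-c2cn(C/C=C3\OC(=O)C(OCc4ccccc4)=C3OCc3ccccc3)nn2)cc1`: > 100000 nM in the cytotoxicity test, a limit.
Compound 2 `CCCCCc1ccc(-c2cn(C/C=C3\OC(=O)C(OCc4ccccc4)=C3OCc3ccccc3)nn2)cc1`: > 100000 nM, a limit.
Compound 3 `CCCCCc1ccc(-c2cn(C[C@H](O)[C@H]3OC(=O)C(OCc4ccccc4)=C3OCc3ccccc3)nn2)cc1`: > 100000 nM, a limit.

In an ADME assay on HFF cells (Homo sapiens) for cytotoxicity, read by MTT assay, with a stated time of 72 h (a higher number here means a weaker inhibitor, a lower number a stronger inhibitor), compound 2 gives > 100000 nM, which is a limit of the assay and not a number. The two further values shown are likewise limits, so compound 2 cannot be placed above or below any companion. The only pairing that differs in one place, butyl in place of hydrogen on a saturated chain carbon bound to an aromatic carbon, is a step that the two limits leave unreadable from compound 1 to compound 2; both ends sit at the limit, so its size is not readable. The evidence that bears on any prediction is therefore (the limit of > 100000 nM in this assay, at which 3 of the 3 values shown sit).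

Compound 4 `O=C1O/C(=C\Cn2cc(-c3cccc(O)c3)nn2)C(OCc2ccccc2)=C1OCc1ccccc1` differs from compound 2 as follows: 3-hydroxyphenyl in place of 4-pentylphenyl on an aromatic carbon. No measured step can be read, so no step beyond the scatter can be predicted; the expectation is that compound 4 again sits at the limit, and a step that the limit leaves unreadable from compound 2 to compound 4 is the step estimated from compound 2. Compound 4 is therefore expected to give about 150000 nM in this assay, with a range from 40000 nM to 600000 nM.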

Compound 4, half-maximal inhibitory concentration: 42600 nM
The estimate for compound 4 lay 3.5-fold (0.55 log units) above the measured number; measured number inside the range.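

In this assay, the group on the aromatic carbon of the five-membered ring is the first change shown to bring a reading off the limit, where the other compounds rest: the limit of > 100000 nM in this assay, at which 3 of the 4 values shown sit. Placing 3-hydroxyphenyl there gives an at least 2.3-fold lower number from compound 2 to compound 4 (0.37 log units; beyond the scatter), and the same group gives an at least 2.3-fold lower number from compound 1 to compound 4 (0.37 log units; beyond the scatter); the true steps may be larger, since each starts from a limit. So this position can alter the reading, which the earlier compounds could not show, as the steps among them cannot be read.

Compound 4 differs from compound 1 and compound 2 in both the hydroxyl group and where the substituent sits on the phenyl ring, and these two changes remain unseparated. A 4-hydroxyphenyl, 3-methoxyphenyl or 3-aminophenyl group in the same place could help tell which of them matters.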